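This account rests on a few compounds, and the source may have more. Where it says the series, first, only, none or still open, it means among the compounds named here.

Compound 1 `O=C(c1cc(-c2ccc(=O)[nH]c2)on1)N1CCC(Cc2ccccc2)CC1`: 19.3 mL/min/kg
Compound 2 `O=C(Nc1ccc2[nH]c(=O)oc2c1)C(=O)N1CCN(c2ccc(Cl)cc2)CC1`: 7.2 mL/min/kg
Compound 3 `O=C1CCc2cc(NC(=O)C(=O)N3CCN(c4ccc(Cl)cc4)CC3)ccc2N1`: "not determined" (no result reported)

In an ADME assay on the whole organism (Rattus norvegicus, strain Sprague-Dawley) for pharmacokinetics, using cassette dosing, at a dose of 0.5 mg/kg by the intravenous route (on this read-out higher numbers stand for fast clearance and lower numbers for slow clearance), compound 2 has the lower of the two available numbers, at 7.2 mL/min/kg. Compound 1, at 19.3 mL/min/kg, lies higher, and that gap is beyond the usual scatter. Compound 3 yielded no number, so it offers no comparison, and compound 1 differs from compound 2 in much more than one place.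

The next compound to be measured is compound 4 `O=C(Nc1ccc2[nH]c(=O)oc2c1)C(=O)N1CCN(c2ccc(Cl)c(F)c2)CC1`. It departs from compound 2 by a single change: fluoro in place of hydrogen on an aromatic carbon. In words, this is fluoro in place of hydrogen on an aromatic carbon, turning 4-chlorophenyl into 4-chloro-3-fluorophenyl. Going by the values given here, no pair of measured compounds shows the effect of such a change, so the data give no direction for it. The step of a 1.0-fold lower number from compound 2 to compound 4 (0.01 log units; within the scatter) is therefore expected to stay within the scatter in this assay. For compound 4 the estimated clearance is 7 mL/min/kg, with an expected range from 3.5 mL/min/kg to 14 mL/min/kg.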

Compound 4, clearance: 5.6 mL/min/kg
Compound 4: the middle estimate sits 1.3-fold (0.10 log units) above what was measured; low and high end bracket the measured number.
By their numbers in this assay, from the lowest: compounds 4 and 2 (each within the scatter of the next); then compound 1.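

In this assay, going by these compounds alone, fluoro in place of hydrogen on an aromatic carbon, ortho to a chloro group, gives a 1.3-fold lower number from compound 2 to compound 4 (0.11 log units; within the scatter), the first step in this set that can be read as a single change. The position therefore accepts a fluoro with clearance staying within the scatter, so 4-chloro-3-fluorophenyl and 4-chlorophenyl cannot be told apart on this read-out. No measurement shown here gives a reason for this outcome.

On these data alone, whether a methyl group, a methoxy group or an amine at the same position would also stay within the scatter remains open, and so does the outcome of fluoro on the other carbons of that ring. As far as these compounds go, it is also open whether the same change would read alike on the core of compound 3, which has no number to start from.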